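Tolerated concentration in Akata cells: from compound 2 to compound 4

This account rests on a few compounds, and the source may have more. Where it says the series, first, only, none or still open, it means among the compounds named here.

Measured so far:
Compound 1, `COCCOc1nc(N)nc2c1ncn2/C=C1/CC1(CO)CO`. In an ADME assay on Akata cells (Homo sapiens) for cytotoxicity, with a stated time of 7 days (a higher number here means that more compound is tolerated, a lower number that less compound is tolerated), compound 1 gives > 20000 nM, which is a limit of the assay.
Compound 2, `CN(C)c1nc(N)nc2c1ncn2/C=C1/CC1(CO)CO`. In this assay compound 2 gives > 24000 nM, which is a limit of the assay.
Compound 3, `CCCCCCCCSc1nc(N)nc2c1ncn2/C=C1/CC1(CO)CO`. In this assay compound 3 gives > 20000 nM, which is a limit of the assay.

Within the data shown here, compound 2 thus stands only at a limit, and the two further values of the series are limits as well; no compound yet gives a number. The three steps among the measured compounds, a step that the two limits leave unreadable from compound 1 to compound 2, a step that the two limits leave unreadable from compound 1 to compound 3 and a step that the two limits leave unreadable from compound 2 to compound 3, are all left unreadable by the limits. The limits concerned are the limit of > 20000 nM in this assay, at which 2 of the 3 values shown sit, and (the limit of > 24000 nM in this assay, at which 1 of the 3 values shown sits).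

Compound 4, `Nc1nc(SC2CCCC2)c2ncn(/C=C3/CC3(CO)CO)c2n1`, differs from compound 2 by cyclopentylsulfanyl in place of dimethylamino on an aromatic carbon. Among the measured compounds shown here, the steps that bear on this change are those involving compound 2 and the one between compound 1 and compound 3, and none of them has a readable size or direction. No step beyond the scatter is therefore expected in this assay, and the step of a number no higher from compound 2 to compound 4 (the limit leaves the size open) is an estimate only. For compound 4 the expected value in this assay is 24000 nM, with a range of 10000 nM to 50000 nM, most likely again reported as a limit.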

Compound 4, half-maximal cytotoxic concentration: > 20000 nM
Compound 4 ended at the assay's limit (the forecaster's own chance of this, stated with the estimate: 80%); the middle value does not contradict the limit.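

In this assay compound 4 gives > 20000 nM, which is a limit of the assay. Among these compounds, no step between compound 4 and compound 1, compound 2 or compound 3 can be read. The compounds shown leave open what number any of the four would give, and whether exchanging the group on the aromatic carbon changes the tolerated concentration at all.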